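Chloro sulfonamide series, effect of a ring substituent

This account rests on a few compounds, and the source may have more. Where it says the series, first, only, none or still open, it means among the compounds named here.

In a functional assay on WiDr cells (Homo sapiens) for antiproliferative activity, read by sulforhodamine B assay, with a stated time of 48 h (a higher number here means a weaker inhibitor of growth, a lower number a stronger inhibitor of growth), compound 1 `Cc1ccc(S(=O)(=O)N2CC[C@@H](Cl)C[C@@H]2c2ccccc2)cc1` gives 37000 nM. Compound 2 `Cc1ccc(S(=O)(=O)N2CCC(Br)CC2)cc1` reaches only the limit of this assay, > 100000 nM. Compound 3 `Cc1ccc(S(=O)(=O)N2CC=C(Cl)CC2)cc1` likewise gives only a limit, > 100000 nM. Going by the values given here, its standing among the three values is therefore known only as a limit, the one at which compound 2 also sits (the limit of > 100000 nM in this assay, at which 2 of the 3 values shown sit). Compound 4 `Cc1ccc(S(=O)(=O)N2CCC(Cl)=CC2C2CCCCC2)cc1` differs from compound 3 by cyclohexyl in place of hydrogen on a saturated ring carbon. Among the compounds with values here, no step between two measured compounds is available. Compound 1, which carries a large group on the ring carbon next to the ring nitrogen, does return a number where compound 3 returns none, so a gain beyond the usual scatter is expected in this assay. Compound 4 is expected at 30000 nM, within 8000 nM to 100000 nM. The expected step is an at least 3.3-fold lower number from compound 3 to compound 4 (0.52 log units; beyond the scatter).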

Compound 4, concentration for 50% growth inhibition: 24000 nM
Compound 4: the middle estimate sits 1.3-fold (0.10 log units) above what was measured, within the range that was stated.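

In this assay, cyclohexyl in place of hydrogen on a saturated ring carbon, next to the ring nitrogen, gives an at least 4.1-fold lower number from compound 3 to compound 4 (0.61 log units; beyond the scatter). From the compounds shown here alone, compound 3 gives > 100000 nM, which is a limit of the assay, so the true size of the step stays unknown. Going by these compounds alone, this is the first step that reads this position directly, with a single change on the shared core.

Going by these compounds, whether the gain needs a carbon ring here stays open. A methyl group, a longer chain or an aminomethyl group on the same carbon would test this.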